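From Phenyl to 4-Bromophenyl: A Cytotoxicity Outlook

This account rests on a few compounds, and the source may have more. Where it says the series, first, only, none or still open, it means among the compounds named here.

Compound 1 `CC1(C)[C@@H]2CC[C@@]1(C)/C(=N/NC(=O)C(F)(F)F)C2`: > 1070000 nM
Compound 2 `CC(=O)N/N=C1\C[C@H]2CC[C@]1(C)C2(C)C`: "not determined" (no result reported)
Compound 3 `CC1(C)[C@@H]2CC[C@@]1(C)/C(=N/NC(=O)c1ccccc1)C2`: > 1040000 nM

In an ADME assay on MDCK cells (Canis lupus familiaris) for cytotoxicity, read by MTT assay, with a stated time of 48 h (on this read-out higher numbers stand for lower toxicity in this test and lower numbers for higher toxicity in this test), compound 3 gives only a limit, > 1040000 nM. Compound 1 likewise sits at a limit, > 1070000 nM, so the step that the two limits leave unreadable from compound 1 to compound 3 cannot be read, as the two limits the limit of > 1040000 nM in this assay, at which 1 of the 3 values shown sits, and the limit of > 1070000 nM in this assay, at which 1 of the 3 values shown sits, show. Compound 2 has no result in this assay.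

Compound 4 `CC1(C)[C@@H]2CC[C@@]1(C)/C(=N/NC(=O)c1ccc(Br)cc1)C2` differs from compound 3 by bromo in place of hydrogen on an aromatic carbon. Going by the values given here, the only measured step, from a trifluoromethyl to a phenyl on the carbonyl carbon, yields no readable size, so no step beyond the scatter can be predicted for this assay. Compound 4 is therefore expected to give a value of about 800000 nM, within 150000 nM to 1500000 nM, which means an expected step of an at least 1.3-fold lower number from compound 3 to compound 4 (0.11 log units; that floor lies within the scatter), most likely reported again as a limit.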

Compound 4, half-maximal cytotoxic concentration: > 822000 nM
Compound 4: only a limit was reported; the forecaster's own chance of this, stated with the estimate: 60%; middle value at least 1.0-fold (0.01 log units) from the limit.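

Compound 4 gives only a limit, > 822000 nM, in this assay. Compound 1 and compound 3 also sit at limits, so no step among these three can be read. The compounds shown leave open whether bromo in place of hydrogen shifts this read-out at all.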